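The compounds below may be only part of what the source reports. "The series", "measured", "known", "first", "only" and "open" are said of these compounds alone.

Within the data shown here, compound 3 `CC(=O)Oc1ccccc1C(=O)O[C@H]1CO[C@H]2[C@@H]1OC[C@H]2OC(=O)c1ccc([N+](=O)[O-])cc1` gives the smallest of the three numbers so far in an ADME assay on a cell-free system (plasma, Homo sapiens) for metabolic stability, with Plasma (Rattus norvegicus) as the target, read by HPLC, at pH 7.4 (on this read-out lower numbers stand for a shorter-lived compound and higher numbers for a longer-lived compound), at 0.0462 h; compound 2 `CC(=O)Oc1ccccc1C(=O)O[C@H]1CO[C@H]2[C@@H]1OC[C@H]2OC(=O)c1ccccc1` gives 0.055 h and compound 1 `CC(=O)Oc1ccccc1C(=O)O[C@H]1CO[C@H]2[C@@H]1OC[C@H]2OC(=O)c1snnc1C` gives 0.0642 h, and the steps of a 1.2-fold lower number from compound 2 to compound 3 (0.08 log units; within the scatter) and a 1.4-fold lower number from compound 1 to compound 3 (0.14 log units; within the scatter) both stay within the scatter, as does a 1.2-fold lower number from compound 1 to compound 2 (0.07 log units; within the scatter). Compound 4 `CC(=O)Oc1ccccc1C(=O)O[C@H]1CO[C@H]2[C@@H]1OC[C@H]2OC(=O)c1ccc(-c2ccccc2)cc1` differs from compound 3 by phenyl in place of nitro on an aromatic carbon. The step that bears on this change is a 1.2-fold lower number from compound 2 to compound 3 (0.08 log units; within the scatter), a swap on the same aromatic carbon that moved nothing beyond the scatter; the other two steps, a 1.2-fold lower number from compound 1 to compound 2 (0.07 log units; within the scatter) and a 1.4-fold lower number from compound 1 to compound 3 (0.14 log units; within the scatter), exchanged whole aroyl groups with the same outcome. No step beyond the scatter is therefore expected in this assay, in either direction. Compound 4 is estimated at 0.05 h, within 0.025 h to 0.1 h, meaning an expected step of a 1.1-fold higher number from compound 3 to compound 4 (0.03 log units; within the scatter).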

Compound 4, half-life: > 0.333 h
Compound 4 was reported as a limit (the forecaster's own chance of this, stated with the estimate: 5%); at least 6.6-fold (0.82 log units) between middle value and limit.
By their numbers in this assay, from the lowest: compounds 3, 2 and 1 (each within the scatter of the next). At a limit, above all of these: compound 4.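

In this assay, compound 4 is reported only as a limit, not a number: the limit of > 0.333 h in this assay, at which 1 of the 4 values shown sits.

On this aromatic carbon, phenyl gives an at least 7.2-fold higher number from compound 3 to compound 4 (0.85 log units; beyond the scatter) and an at least 6.0-fold higher number from compound 2 to compound 4 (0.78 log units; beyond the scatter), whereas the earlier swap of nitro for hydrogen stayed within the scatter. Among these compounds, exchanging the whole aroyl group gives an at least 5.1-fold higher number from compound 1 to compound 4 (0.71 log units; beyond the scatter), so 4-phenylphenyl is the first group to move the half-life beyond the scatter.

From the compounds shown here alone, how far compound 4 lies past its limit remains open. Also open, going by these compounds, is whether an amine, a carboxylic acid or a cyclohexyl ring on this carbon would give a comparable step.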